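Removing the chloro group: from compound 3 to compound 4

This account rests on a few compounds, and the source may have more. Where it says the series, first, only, none or still open, it means among the compounds named here.

Three related compounds have been tested in a functional assay on the whole organism (strain Swiss albino) with Mus musculus as the target; on this read-out higher numbers stand for an effect only at larger amounts of compound and lower numbers for an effect already at smaller amounts. Compound 1 `COc1cc(/C=N/Cc2cccnc2)ccc1O` gives 14.2 mg/kg, and compound 2 `O=[N+]([O-])c1ccc(/C=N/Cc2cccnc2)cc1` gives 22.3 mg/kg. Compound 3 `Clc1ccccc1/C=N/Cc1cccnc1` gives 93.6 mg/kg, the highest of the three numbers; the gaps to compound 2 and to compound 1 both lie beyond the usual scatter of repeated measurements, so compound 3 needs more material than either of the other two to reach the same effect.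

The next compound, compound 4 `C(=N/Cc1cccnc1)\c1ccccc1`, has not yet been measured. It differs from compound 3 in one place: hydrogen in place of chloro on an aromatic carbon. Among the compounds with values here, no earlier pair of measured compounds shows this particular change, so its effect is unknown. The expectation is a step from compound 3 to compound 4 of a 1.9-fold lower number from compound 3 to compound 4 (0.27 log units; within the scatter) in this assay, that is, a modest move toward smaller doses, since the unsubstituted compound may well land between compound 3 and the other two. Compound 4 is therefore estimated at 50 mg/kg, with a likely range from 20 mg/kg to 150 mg/kg.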

Compound 4, dose for half-maximal effect: 62.4 mg/kg
Beside the measured number, compound 4's estimate is 1.2-fold (0.10 log units) below it, within the range that was stated.
By their numbers in this assay, from the lowest: compounds 1 and 2 (each within the scatter of the next); then compounds 4 and 3 (each within the scatter of the next).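

In this assay, removing the chloro group gives a 1.5-fold lower number from compound 3 to compound 4 (0.18 log units; within the scatter), so on this aromatic carbon, ortho to a group of 9 heavy atoms, chloro and hydrogen cannot be told apart by this read-out. Within the data shown here, the nitro group gives the first single-change comparison with a clear result: hydrogen in its place gives a 2.8-fold higher number from compound 2 to compound 4 (0.45 log units; beyond the scatter), meaning that compound 4 needs a larger dose than compound 2 for the same effect. No measurement is available that explains either step.

As far as these compounds go, it remains open whether a fluoro group, an amine or a carboxylic acid on the carbon that carries chloro in compound 3 would shift the dose beyond the scatter. From the compounds shown here alone, it is also open whether nitro would give a similar step on that carbon.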